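The source may hold more compounds than are shown below. What is called first, only, known or untested is meant among the compounds shown, and "the series" means these compounds.

Of the compounds shown here, two that share one core have been measured so far. Compound 1 `c1ccc(Cn2nnc3c(NC4CCCC4)nc(-c4ccccc4)nc32)cc1` carries a cyclopentyl group on a nitrogen attached to an aromatic ring, and in an assay on isolated protein for binding affinity to adenosine receptor A1 (Bos taurus) (a higher number here means a weaker inhibitor, a lower number a stronger inhibitor), compound 1 gives 11000000 nM. Compound 2 `O[C@H]1CCCC[C@@H]1Nc1nc(-c2ccccc2)nc2c1nnn2Cc1ccccc1` carries a 2-hydroxycyclohexyl group in that same position, and in this assay compound 2 gives 10300000 nM. For the measured compounds named here, the only step so far, a 1.1-fold lower number from compound 1 to compound 2 (0.03 log units; within the scatter), lies within the scatter of repeat measurements, so the two numbers cannot be told apart; compound 2 simply stands with the lower of the two numbers, with compound 1 right beside it.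

Compound 3 `CCCNc1nc(-c2ccccc2)nc2c1nnn2Cc1ccccc1` is the next case. The change from compound 2 is propyl in place of 2-hydroxycyclohexyl on a nitrogen on an aromatic ring. Going by the values given here, only the step from compound 1 to compound 2 speaks to what a different group in this position does, and it moved nothing beyond the scatter. With so little to go on, the expectation is that compound 3 also changes little, with a 1.0-fold lower number from compound 2 to compound 3 (0.01 log units; within the scatter) as the estimated step. In this assay compound 3 is therefore expected to give about 10000000 nM, within a range from 3000000 nM to 40000000 nM.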

Compound 3, inhibition constant: 37000000 nM
Estimate against measurement, compound 3: 3.7-fold (0.57 log units) below; low and high end bracket the measured number.
By their numbers in this assay, from the lowest: compounds 2 and 1 (each within the scatter of the next); then compound 3.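

The earlier pair suggested that this position might tolerate any group, but compound 3 shows that the group on the nitrogen can shift the result: in this assay there is a 3.6-fold higher number from compound 2 to compound 3 (0.56 log units; beyond the scatter) and a 3.4-fold higher number from compound 1 to compound 3 (0.53 log units; beyond the scatter), both modest but beyond the scatter. Among these three compounds, the two with a ring in this position sit within the scatter of each other, whether or not that ring carries a hydroxyl group, while the open propyl chain gives the weakest binding, and no compound shown goes against this. Nothing shown here explains why propyl differs from the two ring-bearing groups.

With only one open chain and two different rings, the data cannot separate the presence of a ring from the overall size of the group, since propyl differs from both rings in its atom count as well. On these data alone, a longer chain such as pentyl, a plain cyclohexyl group or a cyclopentyl ring bearing an amine would each test a different part of that question, and how far the trend extends remains open.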